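A few compounds are considered here, and "the series" means these few. Any claim that something is new, unique, unknown or untested is made for them only; others in the source may bear on it.

Compound 1 `COc1ccc(N/C=C\C(=O)c2nc(-c3ccc(F)cc3)n3ccccc23)cc1OC`, compound 2 `O=C(/C=C\Nc1cnc2ccccc2c1)c1nc(-c2ccc(C(F)(F)F)cc2)n2ccccc12` and compound 3 `O=C(/C=C\Nc1ccc2cc[nH]c2c1)c1nc(-c2ccc(C(F)(F)F)cc2)n2ccccc12` share one core and differ only in the group carried on the amine nitrogen. In a functional assay on B16-F10 cells (Mus musculus) for cytotoxicity, read by MTT assay, with a stated time of 48 h (on this read-out lower numbers stand for stronger inhibition and higher numbers for weaker inhibition), compound 1 gives no number but a limit of the assay, > 30000 nM. Compound 2 likewise gives only a limit, > 30000 nM. Compound 3 too gives only a limit, > 30000 nM. All three values sit at the limit of > 30000 nM in this assay, at which 3 of the 3 values shown sit, so compound 3 cannot be placed against the other two beyond that point. Among the compounds with values here, the single measured step, a step that the two limits leave unreadable from compound 2 to compound 3, is not readable in size, and its direction is left open by the two limits.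

Compound 4 `O=C(/C=C\Nc1ccc2[nH]ccc2c1)c1nc(-c2ccc(C(F)(F)F)cc2)n2ccccc12` is the next member. It differs from compound 3 thus: 1H-indol-5-yl in place of 1H-indol-6-yl on an amine nitrogen. Within the data shown here, no measured step bears on this change with a size that can be carried over, since the one recorded step compares two limits. Nothing measured in the series points to compound 4 falling inside the measurable range. The step that the limit leaves unreadable from compound 3 to compound 4 is therefore expected to be none beyond the scatter. Compound 4 is estimated at 40000 nM, with a range from 15000 nM to 150000 nM, and most likely reported again only as a limit.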

Compound 4, half-maximal inhibitory concentration: 18200 nM
The estimate for compound 4 lay 2.2-fold (0.34 log units) above the measured number, and the stated range covers the measured number.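

In this assay compound 4 gives 18200 nM, a number and not a limit of the assay, so 1H-indol-5-yl on the amine nitrogen is the only group among those shown that brings the series into the measurable range. With the same atoms joined differently, 1H-indol-5-yl in place of 1H-indol-6-yl gives an at least 1.6-fold lower number from compound 3 to compound 4 (0.21 log units; that floor lies within the scatter), and 1H-indol-5-yl in place of quinolin-3-yl gives an at least 1.6-fold lower number from compound 2 to compound 4 (0.21 log units; that floor lies within the scatter). Both steps are floors only, so neither shows a change beyond the scatter, and the steps between the other compounds cannot be read, which leaves a single number with nothing measured to size it against: the limit of > 30000 nM in this assay, at which 3 of the 4 values shown sit.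

Still open, from the compounds shown here alone, is how far the true steps reach, and whether the number for compound 4 depends on the free indole hydrogen, which a 1-methylindol-5-yl group on the same amine nitrogen would test. Also open, going by these compounds, is whether 1H-indol-5-yl gives a number with a methoxy or a chloro group in place of the trifluoromethyl on the aryl ring of the shared core.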